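This account rests on a few compounds, and the source may have more. Where it says the series, first, only, none or still open, it means among the compounds named here.

Cytotoxicity numbers in an ADME assay on Vero 76 cells (Chlorocebus sabaeus) for cytotoxicity, read by MTT assay, with a stated time of 96 h (on this read-out higher numbers stand for lower toxicity in this test and lower numbers for higher toxicity in this test), for the three measured compounds:

compound 1 `NS(=O)(=O)c1ccc(N2N=C(c3ccccc3)CC2c2ccccc2F)cc1`: 28000 nM
compound 2 `NS(=O)(=O)c1ccc(N2N=C(c3ccccc3)CC2c2ccccc2Cl)cc1`: 26000 nM
compound 3 `NS(=O)(=O)c1ccc(N2N=C(c3ccc(OCc4ccccc4)cc3)CC2c2cccc(Cl)c2)cc1`: 85000 nM

Compound 2 and compound 1 share a core and differ only by fluoro in place of chloro on an aromatic carbon; this gives a 1.1-fold higher number from compound 2 to compound 1 (0.03 log units; within the scatter). Compound 3 stands on a different core; the difference between the two cores is not broken down here, and its value lies beyond the scatter above both of the others.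

Compound 4 `NS(=O)(=O)c1ccc(N2N=C(c3ccc(OCc4ccccc4)cc3)CC2c2cccc(F)c2)cc1` is not yet measured. It differs from compound 3 by fluoro in place of chloro on an aromatic carbon. This is the same kind of change as that from compound 2 to compound 1, but the place differs: there it is ortho to a large group, here meta to a large group.

For compound 4 in this assay the expected step is a 1.1-fold higher number from compound 3 to compound 4 (0.02 log units; within the scatter), which rests on the earlier step of a 1.1-fold higher number from compound 2 to compound 1 (0.03 log units; within the scatter) being within the scatter. The estimate for compound 4 is 90000 nM, expected between 45000 nM and 180000 nM.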

Compound 4, half-maximal cytotoxic concentration: 90000 nM
For compound 4 middle estimate and measured number coincide at the digits printed, within the range that was stated.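

In this assay, fluoro in place of chloro gives a 1.1-fold higher number from compound 3 to compound 4 (0.02 log units; within the scatter), and the two cores agree on this change: the same change on two cores in this assay, a 1.1-fold higher number (0.03 log units; within the scatter) from compound 2 to compound 1 and a 1.1-fold higher number (0.02 log units; within the scatter) from compound 3 to compound 4, 1.0-fold (0.01 log units) apart, within the scatter of two such steps. Within these two pairs, the swap therefore carries from one core to the other with no step beyond the scatter. This does not give an effect of measurable size to transfer, nor does it separate core from place, as the swap sits at a different place in each pair, and it covers only this cytotoxicity read-out.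

Still open, going by these compounds, is whether a methyl, a methoxy or an amine in place of the chloro would move the number beyond the scatter on either core. No pair shown isolates the difference between the two cores.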